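From a tetrazole amide to a carboxylic acid

The compounds below may be only part of what the source reports. "The series", "measured", "known", "first", "only" and "open" are said of these compounds alone.

Compound 2 `O=C(Nc1nnn[nH]1)c1ccc2occc(=O)c2c1` was tested in a functional assay on the whole organism for inhibition, with Rattus norvegicus as the target, with a stated time of 30 min, at a dose of 1 mg/kg by the intravenous route (a lower number here means less inhibition, a higher number more inhibition at the dose given (going by the name of the read-out)), and gives 35%. Among the measured compounds shown here, this is the only number in the set: for compound 1 `N#Cc1ccc2occc(=O)c2c1` the entry in this assay reads "nd(insoluble)" (no result reported), as it did not dissolve and no result was obtained for it. Compound 3 `O=C(O)c1ccc2occc(=O)c2c1` differs from compound 2 in one place: hydroxy in place of (1H-tetrazol-5-yl)amino on a carbonyl carbon. For the measured compounds named here, no step between measured compounds is available to guide the direction, so a modest fall, possibly not beyond the usual scatter, is the expectation here. For compound 3 the expected result in this assay is 25%, within a range from 5% to 45%. The step this estimate implies, a number 10 percentage points lower from compound 2 to compound 3 (within the scatter), is expected to stay small.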

Compound 3, a percentage reported as inhibition, in the whole organism at one dose (the size of the read-out at that dose, not a potency): 0%
Compound 3: middle estimate off by 25 percentage points, on the high side; measured number below the stated range.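

In this assay, the step of a number 35 percentage points lower from compound 2 to compound 3 (beyond the scatter) shows that the group on this carbonyl carbon matters: with hydroxy in place of (1H-tetrazol-5-yl)amino, no inhibition remains at the dose given. Among the compounds shown here, until now there was a single number and no comparison, so this is the first sign that a change here can alter the result. Nothing available explains the difference between these two compounds.

On these data alone, it remains open whether a primary amide or a methyl ester on the same carbonyl carbon would retain any inhibition. It is also unclear whether the ring in (1H-tetrazol-5-yl)amino is needed.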